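Kir3 series: phenyl-type tetrazole replacing pyridyl

A few compounds are considered here, and "the series" means these few. Any claim that something is new, unique, unknown or untested is made for them only; others in the source may bear on it.

Measured: compound 1 `Cc1cc(NC(=O)Cn2nnc(-c3ccccc3)n2)n(C2CC2)n1` > 5000 nM; compound 2 `O=C(Cn1nnc(-c2ccccc2)n1)Nc1cc(C2CC2)nn1C1CCCCC1` 271 nM; compound 3 `Cc1cc(NC(=O)Cn2nnc(-c3ccccn3)n2)n(C2CCCCC2)n1` 14600 nM.

In an assay on HEK293 cells for activation of Kir3.1/Kir3.2 (Homo sapiens), read by thallium flux (a lower number here means that less compound is needed, a higher number that more compound is needed for the effect), compound 3 gives 14600 nM, the higher of the two numbers shown. Compound 2 gives 271 nM, a gap beyond the scatter. For compound 1 the value is a limit of this assay, not a number. Compound 4 `Cc1cc(NC(=O)Cn2nnc(-c3ccc(F)cc3)n2)n(C2CCCCC2)n1` carries 4-fluorophenyl in place of pyridin-2-yl on an aromatic carbon. Within the data shown here, no step between measured compounds isolates this change, so the expected direction rests on compound 2, whose phenyl-bearing core gives 271 nM; a step toward a lower number, beyond the scatter, is expected as a 7.3-fold lower number from compound 3 to compound 4 (0.86 log units; beyond the scatter). Compound 4 is therefore estimated at 2000 nM, within 300 nM to 15000 nM.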

Compound 4, half-maximal effective concentration: 180 nM
Beside the measured number, compound 4's estimate is 11-fold (1.05 log units) above it; measured number below the stated range.
By their numbers in this assay, from the lowest: compounds 4 and 2 (each within the scatter of the next); then compound 3.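

In this assay, among these compounds, 4-fluorophenyl in place of pyridin-2-yl gives an 81-fold lower number from compound 3 to compound 4 (1.91 log units; beyond the scatter) on the aromatic carbon between two ring nitrogen atoms, the first comparison that differs in one place. This position therefore responds strongly to the ring it carries, with the all-carbon ring bearing fluorine on the low side of this pair. No measured property shown here accounts for the step.

From the compounds shown here alone, the change removes a ring nitrogen and adds a fluorine at once, so which of the two carries the step stays open. A plain phenyl or a pyridin-3-yl on the same core would separate them.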